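Swapping Bromo for Nitro on a Weak Cell-Growth Inhibitor

The source may hold more compounds than are shown below. What is called first, only, known or untested is meant among the compounds shown, and "the series" means these compounds.

Two compounds share one core. In a functional assay on MDA-MB-231 cells (Homo sapiens) for inhibition, read by MTT assay, with a stated time of 72 h (a higher number here means a weaker inhibitor, a lower number a stronger inhibitor), compound 1 `C=CC(=O)Nc1cccc(NC(=O)CSc2nc(Nc3ccccc3C)c3ccccc3n2)c1` gives 20400 nM. For the measured compounds named here, compound 2 `C=CC(=O)Nc1cccc(NC(=O)CSc2nc(Nc3cccc(Br)c3)c3ccccc3n2)c1` gives 19400 nM, the lower of the two numbers, yet the only step measured so far, a 1.1-fold lower number from compound 1 to compound 2 (0.02 log units; within the scatter), stayed within the scatter, so compound 2 sits alongside compound 1 rather than apart from it. Compound 3 `C=CC(=O)Nc1cccc(NC(=O)CSc2nc(Nc3cccc([N+](=O)[O-])c3)c3ccccc3n2)c1` differs from compound 2 by nitro in place of bromo on an aromatic carbon. Going by the values given here, no measured step tests a nitro group, and the one step on that ring moved little, so compound 3 is expected to show no step beyond the scatter, estimated at 20000 nM (range 8000 nM to 50000 nM), a step of a 1.0-fold higher number from compound 2 to compound 3 (0.01 log units; within the scatter).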

Compound 3, half-maximal inhibitory concentration: > 50000 nM
Compound 3: no number, only a limit; the forecaster's own chance of this, stated with the estimate: 10%; middle value at least 2.5-fold (0.39 log units) away from the limit.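

Compound 3 carries no number, only a limit: the limit of > 50000 nM in this assay, at which 1 of the 3 values shown sits.

Even so, this ring position proves sensitive to what sits on it, which the earlier pair did not show: nitro in place of bromo gives an at least 2.5-fold higher number from compound 2 to compound 3 (0.41 log units; beyond the scatter), and 3-nitrophenyl in place of 2-methylphenyl gives an at least 2.4-fold higher number from compound 1 to compound 3 (0.38 log units; beyond the scatter), while the earlier step, a 1.1-fold lower number from compound 1 to compound 2 (0.02 log units; within the scatter), stayed small.

From the compounds shown here alone, how far compound 3 lies past its limit stays open, so the full size of both steps is unknown. Also open, going by these compounds, is whether an amine or a carboxylic acid here would read like compound 2 or like compound 3.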